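The compounds below may be only part of what the source reports. "The series", "measured", "known", "first", "only" and "open" are said of these compounds alone.

In a functional assay on A2780 cells (Homo sapiens) for inhibition, read by sulforhodamine B assay (a lower number here means a stronger inhibitor of growth, a higher number a weaker inhibitor of growth), compound 1 `c1ccc(-c2ccc(-c3ccc(-c4nc5ccccc5[nH]4)cc3)cc2)cc1` gives 32100 nM. Compound 2 `Fc1ccc(-c2ccc(-c3ccc(-c4nc5ccccc5[nH]4)cc3)cc2)cc1`, which has a fluoro in place of a hydrogen on an aromatic carbon, gives 48200 nM. With only these two measurements, compound 2 sits level with compound 1 once the usual scatter is taken into account, and both numbers are in the high micromolar range.

Compound 3 `FC(F)(F)c1ccc(-c2ccc(-c3ccc(-c4nc5ccccc5[nH]4)cc3)cc2)cc1` keeps the core of compound 2 and has trifluoromethyl in place of fluoro on an aromatic carbon, para to a large group: trifluoromethyl in place of fluoro on an aromatic carbon. Within the data shown here, only one measured step bears on this change, made at the same carbon: a 1.5-fold higher number from compound 1 to compound 2 (0.18 log units; within the scatter). That step replaced hydrogen with fluoro and did not move the number beyond the scatter. Among the measured compounds shown here, it is a limited guide, since no trifluoromethyl compound has yet been measured here. Even so, the evidence offers no reason to expect a real shift in this assay, in either direction.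

The expected step is a 1.1-fold lower number from compound 2 to compound 3 (0.03 log units; within the scatter), which is no change beyond the scatter. For compound 3 the estimated value is 45000 nM, with an expected range of 20000 nM to 100000 nM.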

Compound 3, concentration for 50% growth inhibition: 100000 nM
Compound 3: the middle estimate sits 2.2-fold (0.35 log units) below what was measured; the measured number falls inside the stated range.
By their numbers in this assay, from the lowest: compounds 1 and 2 (each within the scatter of the next); then compound 3.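

In this assay, among these compounds, going from 4-fluorophenyl to 4-(trifluoromethyl)phenyl gives a 2.1-fold higher number from compound 2 to compound 3 (0.32 log units; beyond the scatter) and is the first change in this set to pass beyond the scatter. Trifluoromethyl in place of hydrogen on the same aromatic carbon, para to a large group, gives a 3.1-fold higher number from compound 1 to compound 3 (0.49 log units; beyond the scatter) and also passes beyond it, whereas fluoro in place of hydrogen gave a 1.5-fold higher number from compound 1 to compound 2 (0.18 log units; within the scatter) and did not. Both new steps are modest and point towards a weaker inhibitor of growth, so this position does respond to what it carries, but so far the only real shift is a loss of growth inhibition. Nothing measured here explains why trifluoromethyl moves the number while fluoro does not.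

Going by these compounds, how this carbon would respond to a group of another kind, such as an amine, a carboxylic acid or a longer chain, remains open, as does whether any such group could give a lower number than hydrogen. The compounds shown differ only at this one carbon, so they also leave open what a change elsewhere on the shared core would do.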